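The source may hold more compounds than are shown below. What is called first, only, known or untested is meant among the compounds shown, and "the series" means these compounds.

Measured compounds:
- compound 1, `COc1cc(-c2nc3cc(C)c(C)cc3[nH]2)cc(I)c1O`, 1770 nM
- compound 2, `Oc1ccc(-c2nc3cc(F)ccc3[nH]2)c(O)c1`, 2980 nM

The record holds two measured compounds. In an assay for inhibition of Alpha amylase (Homo sapiens), with a stated time of 10 min (a higher number here means a weaker inhibitor, a lower number a stronger inhibitor), compound 1 gives 1770 nM, and in this assay compound 2 gives 2980 nM. The two numbers lie within the usual scatter of each other, so neither compound can be set above or below the other on these data; compound 2 simply sits at the nearer of two close values, with compound 1 as its only comparator.

The step under consideration leads from compound 2 to compound 3, `Oc1ccc(-c2nc3cc(F)ccc3[nH]2)c(O)c1O`. The change is hydroxy in place of hydrogen on an aromatic carbon. Among the compounds with values here, no step between measured compounds is recorded, so nothing measured here tells how large an effect to expect from this change. Only the structural change itself and the two values above can guide the estimate.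

Compound 3 is expected to give a value of 1500 nM in this assay, within a range from 500 nM to 4500 nM. This estimate implies a step of a 2.0-fold lower number from compound 2 to compound 3 (0.30 log units; within the scatter), a modest expected shift toward a lower number that may well stay within the scatter.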

Compound 3, half-maximal inhibitory concentration: 2540 nM
Estimate against measurement, compound 3: 1.7-fold (0.23 log units) below, within the range that was stated.
By their numbers in this assay, from the lowest: compounds 1, 3 and 2 (each within the scatter of the next).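

In this assay, the change from hydrogen to hydroxy on this aromatic carbon, ortho to two hydroxy groups and meta to a large group, amounts to a 1.2-fold lower number from compound 2 to compound 3 (0.07 log units; within the scatter). This is the only direct reading of a single change among the compounds shown, and it indicates that, on this core, the added hydroxy does not separate compound 3 from compound 2 by more than the usual scatter of the assay. No supporting measurement bears on why the step has this size.

On these data alone, whether this carbon is generally insensitive to substitution remains open, since a single hydroxy step cannot show whether an amine or a carboxylic acid in the same place would give a number beyond the scatter. As far as these compounds go, it is equally open whether the hydroxy would have a similarly small step on the core of compound 1, which differs from compound 2 in several places and so offers no comparison for this change.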